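A Dihydroxyethyl Side Chain on an Inactive Core

The source may report more compounds than this note shows. Statements on the series, on what has been measured and on what is new or still open speak of the compounds shown alone.

In a functional assay for inhibition, with Homo sapiens as the target (on this read-out higher numbers stand for weaker inhibition and lower numbers for stronger inhibition), compound 1 `O=C(CSc1nncc2cncn12)c1ccccc1` gives > 48000 nM, which is a limit of the assay rather than a number.
In this assay compound 2 `CCCc1nc(C)c2cnn(CC)c(=O)n12` gives > 48000 nM, again a limit.
In this assay compound 3 `CCCc1nnc(SC)n2c(CCC)nc(C)c12` gives > 48000 nM, also a limit.

Going by the values given here, every measured compound sits at the limit of > 48000 nM in this assay, at which 3 of the 3 values shown sit, so none of the three shows measurable inhibition and no step between two actual numbers can be compared. Compound 2 therefore stands level with the other two on the numbers shown; nothing separates it from them.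

Compound 4 `CCCc1nc(C)c2cnn(CC(O)CO)c(=O)n12` is built from compound 2 by one change: 1,2-dihydroxyethyl in place of methyl on a saturated chain carbon bound to an aromatic nitrogen. The methyl leaves and a 1,2-dihydroxyethyl enters on the saturated chain carbon bound to the aromatic nitrogen; read one bond further out, an ethyl becomes a 2,3-dihydroxypropyl. The core of compound 2 is kept unchanged.

Because compound 2 sits at the limit of > 48000 nM in this assay, at which 3 of the 3 values shown sit, no measured step size is available to guide the expectation. In this assay the step that the limit leaves unreadable from compound 2 to compound 4 is expected to stay within the scatter, and most likely the assay will again report only a limit. Compound 4 is estimated at 60000 nM, in the range 20000 nM to 200000 nM.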

Compound 4, half-maximal inhibitory concentration: > 48000 nM
Compound 4: only a limit was reported (the forecaster's own chance of this, stated with the estimate: 85%); the middle value is on the limit's open side.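

Compound 2 and compound 4 both end at a limit of the assay rather than at a number, so no step can be read between them: the limit of > 48000 nM in this assay, at which 4 of the 4 values shown sit.

The compounds shown leave open whether any of them has measurable inhibition in this assay, and whether placing 1,2-dihydroxyethyl in place of methyl changes inhibition at all.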